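Swapping the dichlorophenyl ketone for a dimethoxyphenyl ketone

The source may hold more compounds than are shown below. What is called first, only, known or untested is meant among the compounds shown, and "the series" means these compounds.

This account follows two measured compounds and one that awaits measurement. Compound 1 `COc1cc(-c2cc(/C=C/C(=O)c3ccc(Cl)c(Cl)c3)[nH]n2)cc(OC)c1OC` was tested in a functional assay on UACC-257 cells (Homo sapiens) for cytotoxicity, read by sulforhodamine B assay, with a stated time of 48 h, tested at 100 uM (on this read-out higher numbers stand for a weaker effect at the one concentration tested and lower numbers for a stronger effect), and gives -10%. Compound 2 `COc1ccc(-c2cc(/C=C/C(=O)c3ccc(N)cc3)[nH]n2)cc1`, which shares the same overall skeleton but carries different groups at both ends, gives -95% in this assay. Of the two numbers, compound 1 stands highest, which on this read-out means the weaker effect at the single concentration tested, and the gap to compound 2 lies beyond the usual scatter.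

Compound 3 `COc1ccc(C(=O)/C=C/c2cc(-c3cc(OC)c(OC)c(OC)c3)n[nH]2)cc1OC` differs from compound 1 in one place: 3,4-dimethoxyphenyl in place of 3,4-dichlorophenyl on a carbonyl carbon. Among the measured compounds shown here, no pair of measured compounds shows this particular change on its own, so nothing directly tells how large a step to expect. For the measured compounds named here, because compound 1 gives -10% while the only other measured compound shows a far stronger effect, there is room for compound 3 to move toward a stronger effect. The step from compound 1 to compound 3 is expected to be a number 20 percentage points lower from compound 1 to compound 3 (beyond the scatter), a modest shift toward a stronger effect, though it could well stay within the scatter. Compound 3 is therefore estimated at -30%, with a range from -75% to 10%.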

Compound 3, a percentage reported as activity, at one concentration (the size of the read-out at that concentration, not a potency): -97%
Estimate against measurement, compound 3: 67 percentage points above; measured number below the stated range.
By their numbers in this assay, from the lowest: compounds 3 and 2 (each within the scatter of the next); then compound 1.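

Among the compounds shown here, exchanging the 3,4-dichlorophenyl group for 3,4-dimethoxyphenyl on a carbonyl carbon gives a number 87 percentage points lower from compound 1 to compound 3 (beyond the scatter) in this assay, the first change in this set that can be read in one place alone. It shows that the read-out at this single concentration depends strongly on the group at this position, even with the rest of compound 1 unchanged. The entering group brings hydrogen-bond acceptors and the leaving group has none, but the two also differ in their atoms and size, and no measurement at hand bears on what lies behind the step.

Still open, as far as these compounds go, is whether the step follows from gaining the methoxy groups or from losing the chlorine atoms, a question that an unsubstituted phenyl group or a phenyl group with methyl groups at this carbonyl carbon could help to separate. Also open, from the compounds shown here alone, is whether the same exchange would give a step of similar size with a different group at the other end of the shared core, such as a single methoxy group or a carboxylic acid on that ring.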